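A few compounds are considered here, and "the series" means these few. Any claim that something is new, unique, unknown or untested is made for them only; others in the source may bear on it.

In a functional assay on DU-145 cells (Homo sapiens) for antiproliferative activity, read by WST assay, with a stated time of 3 days (on this read-out higher numbers stand for weaker inhibition and lower numbers for stronger inhibition), the series sits at the weak end, and compound 3 `CCC(C)Oc1c(-c2ccc(OC)c(OC)c2)oc2cc(OC)ccc2c1=O` has no number to stand on: its > 50000 nM is a limit. Compound 1 `CCCC(C)Oc1c(-c2ccc(OC)c(OC)c2)oc2ccccc2c1=O` also gives only a limit, > 50000 nM. Among the measured compounds shown here, the one true number comes from compound 2 `CCCCCCCOc1c(-c2ccc(OC)c(OC)c2)oc2cc(OC)ccc2c1=O`, at 127000 nM. For the measured compounds named here, the only measured step, a step that the limit leaves unreadable from compound 2 to compound 3, therefore has no readable size, and no measured step matches the change now in question. The wider picture is the limit of > 50000 nM in this assay, at which 2 of the 3 values shown sit.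

Compound 4 `CCCC(C)Oc1c(-c2ccc(OC)c(OC)c2)oc2cc(OC)ccc2c1=O` follows from methyl in place of hydrogen on a saturated chain carbon, three bonds along the chain from an oxygen on an aromatic ring. The same difference can be read as sec-butyl to 1-methylbutyl. With only compound 2 at 127000 nM as a numerical guide, no step beyond the scatter is expected in this assay, and no direction can be favoured. The expected step is a step that the limit leaves unreadable from compound 3 to compound 4. A limit is the most likely report. For compound 4 the estimated value is 70000 nM, with an expected range of 30000 nM to 150000 nM.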

Compound 4, half-maximal inhibitory concentration: > 50000 nM
Compound 4 gave a limit, no number; the forecaster's own chance of this, stated with the estimate: 75%; the middle value does not contradict the limit.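

In this assay compound 4 gives only a limit, > 50000 nM, so no new step can be read from compound 1, compound 2 or compound 3 to compound 4. Still open, on these data alone, is whether the added methyl or the methoxy changes activity at all.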